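Swapping cyclohexyl for 4-(trifluoromethoxy)phenyl: stability expectation

A few compounds are considered here, and "the series" means these few. Any claim that something is new, unique, unknown or untested is made for them only; others in the source may bear on it.

For the measured compounds named here, compound 1 `CCc1nc2ccc(Cl)cn2c1C(=O)NCc1ccc2oc(C3CCCCC3)nc2c1` stands highest of the two numbers so far in an ADME assay on microsomes from liver (Homo sapiens) for metabolic stability (a higher number here means that the compound lasts longer, a lower number that the compound disappears faster), where compound 1 gives 0.283 h. Compound 2 `CCc1nc2ccc(Cl)cn2c1C(=O)NCc1ccc2ccccc2c1` gives 0.115 h in this assay, a lower number, and the gap between these two lies beyond the usual scatter. Compound 3 `CCc1nc2ccc(Cl)cn2c1C(=O)NCc1ccc2oc(-c3ccc(OC(F)(F)F)cc3)nc2c1`, not yet measured, differs from compound 1 by 4-(trifluoromethoxy)phenyl in place of cyclohexyl on an aromatic carbon. Going by the values given here, no step between measured compounds shows what such a change does, so the direction rests on expectation only. For compound 3 the step of a 1.2-fold higher number from compound 1 to compound 3 (0.09 log units; within the scatter) is expected to be small, with no sure direction beyond the scatter. Compound 3 is estimated at 0.35 h, between 0.15 h and 0.8 h.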

Compound 3, half-life: > 2 h
Compound 3 was reported as a limit; the forecaster's own chance of this, stated with the estimate: 5%; middle value at least 5.7-fold (0.75 log units) from the limit.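

In this assay, the group on this aromatic carbon of the five-membered ring decides much of the outcome: 4-(trifluoromethoxy)phenyl in place of cyclohexyl gives an at least 7.0-fold higher number from compound 1 to compound 3 (0.84 log units; beyond the scatter). Compound 3 gives > 2 h, a limit of the assay and not a number, so only the lower end of the step can be read: the limit of > 2 h in this assay, at which 1 of the 3 values shown sits.

The compounds shown do not separate the aromatic ring from its trifluoromethoxy group. A plain phenyl or a 4-methoxyphenyl on this carbon would make that comparison.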